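Swapping a Long Sulfur Chain for Propoxy: Expected Cytotoxicity

The compounds below may be only part of what the source reports. "The series", "measured", "known", "first", "only" and "open" are said of these compounds alone.

Compound 2 `CCCCCCCCSc1nc(N)nc2c1ncn2/C=C1/CC1(CO)CO` was tested in an ADME assay on MOLT-3 cells (Homo sapiens) for cytotoxicity, with a stated time of 7 days; a higher number here means that more compound is tolerated, a lower number that less compound is tolerated. In this assay compound 2 reaches only the assay limit, > 20000 nM. Compound 1 `COCCOc1nc(N)nc2c1ncn2/C=C1/CC1(CO)CO` likewise shows only a limit of > 20000 nM. The step that the two limits leave unreadable from compound 1 to compound 2 cannot be read, since (the limit of > 20000 nM in this assay, at which 2 of the 2 values shown sit). Compound 3 `CCCOc1nc(N)nc2c1ncn2/C=C1/CC1(CO)CO` differs from compound 2 in one place: propoxy in place of octylsulfanyl on an aromatic carbon. Going by the values given here, the one measured step touches this position but has no readable size, so no step beyond the scatter is expected. Compound 3 is therefore expected to sit at 20000 nM, between 10000 nM and 40000 nM. The expected step is a number no higher from compound 2 to compound 3 (the limit leaves the size open), most likely again only a limit.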

Compound 3, half-maximal cytotoxic concentration: > 20000 nM
Compound 3 was reported as a limit; the forecaster's own chance of this, stated with the estimate: 85%; the middle value sits exactly at the limit.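

No step between compound 1, compound 2 and compound 3 can be read in this assay, because all three report only a limit: the limit of > 20000 nM in this assay, at which 3 of the 3 values shown sit.

The compounds shown leave open whether 2-methoxyethoxy, octylsulfanyl or propoxy on the aromatic carbon makes any difference to cytotoxicity.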